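The compounds below may be only part of what the source reports. "The series", "measured", "known", "first", "only" and "open" are said of these compounds alone.

Compound 2 `FC(F)(F)c1ccc(CN2CCN(Cc3cc(-c4ccc(OCc5ccc(Cl)cc5)cc4)on3)CC2)cc1` gives 6700 nM in a functional assay on MCF7 cells (Homo sapiens) for antiproliferative activity, read by sulforhodamine B assay, with a stated time of 72 h (on this read-out lower numbers stand for stronger inhibition and higher numbers for weaker inhibition), the highest of the two numbers measured, while compound 1 `Cc1ccccc1COc1ccc(-c2cc(CN3CCN(Cc4ccc(C(F)(F)F)cc4)CC3)no2)cc1` gives 3700 nM in this assay. Among the measured compounds shown here, the single step measured so far, a 1.8-fold higher number from compound 1 to compound 2 (0.26 log units; within the scatter), concerns a change at the benzyl group, 4-chlorophenyl in place of 2-methylphenyl on a saturated chain carbon bound to an oxygen on an aromatic ring, and lies within the scatter.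

Compound 3 `COc1ccc(COc2ccc(-c3cc(CN4CCN(Cc5ccc(C(F)(F)F)cc5)CC4)no3)cc2)cc1` differs from compound 2 at the same end of the molecule: methoxy in place of chloro on an aromatic carbon. No measured step swaps chloro for methoxy on this ring, so the only guide is the general tolerance of this position shown by the step from compound 1 to compound 2, which was within the scatter. On that basis compound 3 is expected to show a step of about a 1.1-fold lower number from compound 2 to compound 3 (0.05 log units; within the scatter) in this assay, with no change beyond the scatter in either direction. The estimate for compound 3 in this assay is therefore 6000 nM, with a range from 2500 nM to 15000 nM.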

Compound 3, half-maximal inhibitory concentration: 1300 nM
Beside the measured number, compound 3's estimate is 4.6-fold (0.66 log units) above it; the whole stated range lies above it.
By their numbers in this assay, from the lowest: compound 3; then compounds 1 and 2 (each within the scatter of the next).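

In this assay, among the compounds shown here, the step from chloro to methoxy shows that this aromatic carbon, para to a large group, is not indifferent to what it carries: the change gives a 5.2-fold lower number from compound 2 to compound 3 (0.71 log units; beyond the scatter), whereas the only earlier step at this end of the molecule stayed within the scatter. The 4-methoxyphenyl group also separates from the 2-methylphenyl group, with a 2.8-fold lower number from compound 1 to compound 3 (0.45 log units; beyond the scatter), so compound 3 has the lowest number of the three, and its steps to both other compounds lie beyond the scatter. No measurement is available here that explains why methoxy and chloro differ at this position.

On these data alone, it remains open whether a hydroxyl, an ethoxy or a dimethylamino group on the same aromatic carbon would track methoxy or chloro in this assay, and so whether the lower number belongs to methoxy alone. As far as these compounds go, all three compounds also share the same trifluoromethyl group at the other end, so it is unknown whether the step from chloro to methoxy would keep its size with a nitrile there instead.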